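Compound 4: methylsulfonyl in place of trifluoromethoxy

This account rests on a few compounds, and the source may have more. Where it says the series, first, only, none or still open, it means among the compounds named here.

In an ADME assay on BJ cells (Homo sapiens) for cytotoxicity, read by CellTiter-Glo and resazurin assay, with a stated time of 72 h (on this read-out lower numbers stand for an effect already at smaller amounts and higher numbers for an effect only at larger amounts of compound), compound 3 (`CCOC(=O)CCCCCOc1cccc(CN(C(=O)c2ccc(-c3cccc(OC(F)(F)F)c3)cc2)C(C)C)c1`) gives > 26000 nM as a limit and not a number. Compound 1 (`CCOC(=O)CCCCCOc1cccc(CN(C(=O)c2ccc(-c3cccnc3)cc2)C(C)C)c1`) gives > 26000 nM as a limit too. Compound 2 (`CCOC(=O)CCCCCOc1cccc(CN(C(=O)c2ccc(-c3cccc(OC)c3)cc2)C(C)C)c1`) gives > 21000 nM as a limit too. Compound 4 (`CCOC(=O)CCCCCOc1cccc(CN(C(=O)c2ccc(-c3cccc(S(C)(=O)=O)c3)cc2)C(C)C)c1`) carries methylsulfonyl in place of trifluoromethoxy on an aromatic carbon is the change. The measured changes bearing on it are a step that the two limits leave unreadable from compound 1 to compound 3 and a step that the two limits leave unreadable from compound 2 to compound 3 and a step that the two limits leave unreadable from compound 1 to compound 2 with no size to carry over. The expected outcome, with no direction favoured, is an at least 1.0-fold lower number from compound 3 to compound 4 (0.01 log units; that floor lies within the scatter) as a weakly supported expectation. In this assay compound 4 is estimated at 25000 nM with 12000 nM as lower end and 40000 nM as upper end of the range.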

Compound 4, half-maximal effective concentration: > 26000 nM
Compound 4: only a limit was reported (the forecaster's own chance of this, stated with the estimate: 75%); middle value at least 1.0-fold (0.01 log units) from the limit.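

Compound 4 is reported only as a limit, as are compound 1, compound 2 and compound 3, so no step among them can be read: the limit of > 26000 nM in this assay, at which 3 of the 4 values shown sit.

From the compounds shown here alone, whether these compounds differ at all, and at what concentration any of them would show an effect, stays open.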